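A chloroquinazoline swap tested on a second benzyl ether

The source may report more compounds than this note shows. Statements on the series, on what has been measured and on what is new or still open speak of the compounds shown alone.

Three compounds were tested in a functional assay on SMMC-7721 cells (Homo sapiens) for inhibition, read by MTT assay, with a stated time of 72 h, tested at 1 uM; on this read-out lower numbers stand for a weaker effect and higher numbers for a stronger effect at the one concentration tested. Compound 1 `Cc1cccc2ncnc(O/N=C(\C=C\c3ccccn3)/C=C/c3ccccc3OCc3ccccc3Cl)c12` gave 86.8%, compound 2 `Clc1ccc2c(O/N=C(\C=C\c3ccccn3)/C=C/c3ccccc3OCc3ccccc3Cl)ncnc2c1` gave 94.8% and compound 3 `Cc1cccc2ncnc(O/N=C(\C=C\c3ccccn3)/C=C/c3ccccc3OCc3ccc(Cl)cc3)c12` gave 93.4%.

Compound 2 arises from compound 1 by the change (7-chloroquinazolin-4-yl in place of 5-methylquinazolin-4-yl on an oxygen), and in this assay this step was a number 8 percentage points higher from compound 1 to compound 2 (within the scatter). Compound 3 arises from compound 1 by the change (4-chlorophenyl in place of 2-chlorophenyl on a saturated chain carbon bound to an oxygen on an aromatic ring), a rearrangement of the same atoms, and in this assay that step was a number 6.6 percentage points higher from compound 1 to compound 3 (within the scatter). Both steps sit inside the scatter of repeated measurements, so the three compounds cannot be ordered against one another on this read-out.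

Compound 4 `Clc1ccc(COc2ccccc2/C=C/C(/C=C/c2ccccn2)=N/Oc2ncnc3cc(Cl)ccc23)cc1` has not yet been measured. It differs from compound 3 by 7-chloroquinazolin-4-yl in place of 5-methylquinazolin-4-yl on an oxygen, the same change that separates compound 2 from compound 1, made at the same place on the same oxygen. This change has been seen once among the measured compounds. Since compound 3 already gives a high number and the earlier step of this kind was a number 8 percentage points higher from compound 1 to compound 2 (within the scatter), compound 4 is expected to land near the upper end of the range, with a step of a number 1.6 percentage points higher from compound 3 to compound 4 (within the scatter), held in check by the ceiling of the read-out. Compound 4 is therefore estimated at 95% in this assay, between 87% and 99%.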

Compound 4, a percentage reported as inhibition, at one concentration (the size of the read-out at that concentration, not a potency): 94%
For compound 4 the middle estimate is 1 percentage points above the measured one, and the stated range covers the measured number.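

In this assay the change to 7-chloroquinazolin-4-yl from 5-methylquinazolin-4-yl on the oxygen, now carried onto the benzyl ether of compound 3, gave a number 0.6 percentage points higher from compound 3 to compound 4 (within the scatter), and set beside its first appearance it reads: the same change on two cores in this assay, a number 8 percentage points higher (within the scatter) from compound 1 to compound 2 and a number 0.6 percentage points higher (within the scatter) from compound 3 to compound 4, 7.4 percentage points apart, within the scatter of two such steps. The change to 4-chlorophenyl from 2-chlorophenyl, carried in turn onto the core of compound 2, gave a number 0.8 percentage points lower from compound 2 to compound 4 (within the scatter), and the comparison reads: the same change on two cores in this assay, a number 6.6 percentage points higher (within the scatter) from compound 1 to compound 3 and a number 0.8 percentage points lower (within the scatter) from compound 2 to compound 4, 7.4 percentage points apart, within the scatter of two such steps. Each change therefore gave steps on its two cores that cannot be told apart on this read-out, but since every one of these steps lies within the scatter, the data do not show that either change has any effect of its own, nor that the two changes add up or interact.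

With only one concentration tested and all four compounds giving high numbers, the compounds shown leave open whether these steps would separate under conditions where the read-out has more room to move. They also leave open how an amine or a carboxylic acid would behave in place of the chlorine on the 7-chloroquinazolin-4-yl group.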